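The source may hold more compounds than are shown below. What is called first, only, known or untested is meant among the compounds shown, and "the series" means these compounds.

In a functional assay on HT-29 cells (Homo sapiens) for inhibition, read by sulforhodamine B assay, with a stated time of 48 h (a lower number here means a stronger inhibitor of growth, a higher number a weaker inhibitor of growth), compound 1 (`S=C(N/N=C/c1cccs1)Nc1ccc(Cl)cc1`) gives > 100000 nM, which is a limit of the assay and not a number. Compound 2 (`CCc1ccc(NC(=S)N/N=C/c2cccs2)cc1`) gives > 100000 nM, which is also a limit. Compound 2 therefore has no numerical position, and the evidence amounts to the limit of > 100000 nM in this assay, at which 2 of the 2 values shown sit.

Compound 3 (`S=C(N/N=C/c1cccs1)Nc1ccc(Br)cc1`) differs from compound 2 by bromo in place of ethyl on an aromatic carbon, para to a large group. Going by the values given here, only one measured step bears on this change, a step that the two limits leave unreadable from compound 1 to compound 2, where ethyl replaces chloro on an aromatic carbon. That step has no readable size, so it offers no magnitude or direction to carry over. Compound 3 does carry bromo where compound 1 carries chloro, but that comparison gives no number either. No readable shift is therefore expected in this assay, and the estimate stays close to the limit reached by both measured compounds. The expected change is a number no higher from compound 2 to compound 3 (the limit leaves the size open). Compound 3 is expected to give about 100000 nM, with an estimated range from 40000 nM to 200000 nM.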

Compound 3, concentration for 50% growth inhibition: 17700 nM
Compound 3: middle estimate off by 5.6-fold (0.75 log units), on the high side, and the stated range ends above it.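

At this place on the six-membered aromatic ring, para to a large group, the choice of substituent can produce a readable change in this assay: bromo in place of ethyl gives an at least 5.6-fold lower number from compound 2 to compound 3 (0.75 log units; beyond the scatter), and bromo in place of chloro gives an at least 5.6-fold lower number from compound 1 to compound 3 (0.75 log units; beyond the scatter). Compound 3 is the only one of the three compounds shown with a number rather than a limit, so this single change of substituent separates it from both of the others, whereas the earlier step between the chloro and ethyl compounds cannot be read. Chloro and ethyl remain unordered, and the two compounds carrying them stay at the limit of the assay: the limit of > 100000 nM in this assay, at which 2 of the 3 values shown sit.

From the compounds shown here alone, the full size of both new steps remains open, since each is bounded on one side only, and it is also unclear whether the change seen here is particular to bromo. Whether iodo, methoxy or an amine at this same place would also give a number remains unanswered, as does the outcome of moving bromo elsewhere on the ring.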